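Substituent change on the ring amide-type nitrogen: compound 3

The source may report more compounds than this note shows. Statements on the series, on what has been measured and on what is new or still open speak of the compounds shown alone.

Measured compounds in a functional assay on the whole organism (blood, strain albino) with Mus musculus as the target, with stated times of 6 days and 3 h, at a dose of 1 mmol/kg by the oral route; on this read-out higher numbers stand for more inhibition at the one dose given (going by the name of the read-out) and lower numbers for less inhibition:
compound 1 `CCCCN1C(=O)CCN(S(=O)(=O)c2ccc(-n3nc(C(=O)O)cc3C)cc2)C1=S` gives 2%
compound 2 `C=CCN1C(=O)CCN(S(=O)(=O)c2ccc(-n3nc(C(=O)O)cc3C)cc2)C1=S` gives 0%

Compound 2 stands lowest of the two numbers shown; its nearest neighbour is compound 1, and the step of a number 2 percentage points lower from compound 1 to compound 2 (within the scatter) lies within the scatter, so the two compounds cannot be told apart on this read-out. Both sit close to the bottom of the scale.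

Compound 3 `Cc1cc(C(=O)O)nn1-c1ccc(S(=O)(=O)N2CCC(=O)N(c3ccccc3)C2=S)cc1` has not yet been measured. It differs from compound 2 as follows: phenyl in place of allyl on an amide-type nitrogen in a ring. Among the measured compounds shown here, the only measured step, from compound 1 to compound 2, also concerns the group on this ring nitrogen, but it exchanges one chain for another, and it was within the scatter. It therefore gives little guidance on a phenyl entering in place of allyl; what it does show is that the read-out has so far not moved with the group at this position. On that basis no step beyond the scatter is expected, a number 4 percentage points higher from compound 2 to compound 3 (within the scatter). Compound 3 is accordingly estimated to give 4%, with a range from 0% to 18%.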

Compound 3, a percentage reported as inhibition, in the whole organism at one dose (the size of the read-out at that dose, not a potency): 1%
Estimate against measurement, compound 3: 3 percentage points above; the measured number falls inside the stated range.
By their numbers in this assay, from the lowest: compounds 2, 3 and 1 (each within the scatter of the next).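

In this assay the step with phenyl in place of allyl is a number 1 percentage points higher from compound 2 to compound 3 (within the scatter) and the step with phenyl in place of butyl is a number 1 percentage points lower from compound 1 to compound 3 (within the scatter) on the same ring nitrogen. The earlier pair compared only open chains, whereas these steps show that a group of 6 heavy atoms with one six-membered aromatic ring of carbon only cannot be told apart on this read-out from allyl, with its 3 heavy atoms and no ring, or from butyl. The series therefore shows no gain from placing an aromatic ring on the amide-type nitrogen, but all three compounds sit close to the bottom of the scale, so this does not establish that the group has no influence where inhibition is greater.

Still open, on these data alone, is whether an aminoethyl group, a benzyl group or a longer chain on this nitrogen would lift the number away from the bottom of the scale. Also open, as far as these compounds go, is whether a phenyl bearing a methoxy group or a chlorine atom would behave as the plain phenyl does.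

No measurement at hand bears on the reason for these numbers.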